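This account rests on a few compounds, and the source may have more. Where it says the series, first, only, none or still open, it means among the compounds named here.

Working notes on the series. Three measured compounds share one core and carry an allyl chain on a ring nitrogen next to a short alkyl on an aromatic carbon: compound 1 `C=CCn1ncc2c(C)nc(CC)n2c1=O`, compound 2 `C=CCn1ncc2c(C)nc(C(C)C)n2c1=O` and compound 3 `C=CCn1ncc2c(C)nc(CCC)n2c1=O`. In a functional assay for inhibition, with Homo sapiens as the target (a higher number here means a weaker inhibitor, a lower number a stronger inhibitor), compound 3 gives 40000 nM. Compound 1 reaches only the limit of the assay, > 48000 nM. Compound 2 likewise stops at the limit, > 48000 nM. The steps among the three are small or unreadable: a step that the two limits leave unreadable from compound 1 to compound 2, an at least 1.2-fold lower number from compound 1 to compound 3 (0.07 log units; that floor lies within the scatter) and an at least 1.2-fold lower number from compound 2 to compound 3 (0.07 log units; that floor lies within the scatter), all read against (the limit of > 48000 nM in this assay, at which 2 of the 3 values shown sit).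

Compound 4 `CCn1ncc2c(C)nc(C(C)C)n2c1=O` differs from compound 2 by methyl in place of vinyl on a saturated chain carbon bound to an aromatic nitrogen; cut one bond further out, the same difference reads allyl to ethyl. Among the compounds with values here, none of the measured steps touches this chain; all three alter the alkyl on the aromatic carbon, and two of them end at the limit. For compound 2 itself only a floor is known. No step beyond the scatter has been seen in this set, so compound 4 is expected to stay near the limit, and a step that the limit leaves unreadable from compound 2 to compound 4 is the expected step, nothing beyond the scatter. The estimate for compound 4 in this assay is 50000 nM, within 25000 nM to 100000 nM, and most likely the assay again reports only a limit.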

Compound 4, half-maximal inhibitory concentration: > 48000 nM
Compound 4 ended at the assay's limit; the forecaster's own chance of this, stated with the estimate: 70%; the middle value does not contradict the limit.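

Compound 2 and compound 4 both stop at the limit of this assay, so no step can be read between them, because neither gives a number: the limit of > 48000 nM in this assay, at which 3 of the 4 values shown sit.

The compounds shown leave open whether allyl to ethyl on this chain changes the read-out in this assay at all, as this difference appears only between two limits.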